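The source may hold more compounds than are shown below. What is called first, only, known or untested is meant among the compounds shown, and "the series" means these compounds.

In an assay on brain (strain Sprague-Dawley) for inhibition of Amine oxidase [flavin-containing] B (Rattus norvegicus), read by spectrophotometry (on this read-out higher numbers stand for weaker inhibition and lower numbers for stronger inhibition), three compounds sharing one core have been measured. Compound 1 `O=C(O)c1cc(=O)oc2cc(OCc3cccc(Cl)c3)ccc12` gives 100000 nM. Compound 2 `O=C(O)COc1cc(=O)oc2cc(OCc3cccc(Cl)c3)ccc12` gives 31600 nM. Compound 3 `O=c1cc(CCCl)c2ccc(OCc3cccc(Cl)c3)cc2o1` gives 12.9 nM, the lowest of the three numbers, and both others lie far from it: there is a 7800-fold lower number from compound 1 to compound 3 (3.89 log units; beyond the scatter) and a 2400-fold lower number from compound 2 to compound 3 (3.39 log units; beyond the scatter). Between the two weaker compounds there is only a 3.2-fold lower number from compound 1 to compound 2 (0.50 log units; beyond the scatter).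

Compound 4 `NC(=O)CCc1cc(=O)oc2cc(OCc3cccc(Cl)c3)ccc12` has not yet been measured. It differs from compound 3 in a single place: carbamoyl in place of chloro on a saturated chain carbon, two bonds along the chain from an aromatic carbon. Going by the values given here, the steps that bear on this are the two large falls that arrived at compound 3, in which a carboxy or a carboxymethoxy group on the aromatic carbon was exchanged for the 2-chloroethyl chain. The change to compound 4 runs partly back the other way, keeping the chain but ending it in a carbamoyl group rather than a chlorine. A rise in the number is therefore expected for compound 4, though not the full height of the earlier falls, since the chain itself stays in place; the expected step is a 78-fold higher number from compound 3 to compound 4 (1.89 log units; beyond the scatter). Compound 4 is estimated at 1000 nM, with a range from 100 nM to 10000 nM.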

Compound 4, half-maximal inhibitory concentration: 15.1 nM
The estimate for compound 4 lay 66-fold (1.82 log units) above the measured number; measured number below the stated range.
By their numbers in this assay, from the lowest: compounds 3 and 4 (each within the scatter of the next); then compound 2; then compound 1.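

In this assay the end of the chain can change from chloro to carbamoyl, a larger group that brings a hydrogen-bond donor and acceptor, and the outcome is a 1.2-fold higher number from compound 3 to compound 4 (0.07 log units; within the scatter), so the two compounds cannot be told apart. The earlier compounds shown here tied the low number to the 2-chloroethyl chain alone, but the 2-carbamoylethyl chain stands just as far from the other two, with a 2100-fold lower number from compound 2 to compound 4 (3.32 log units; beyond the scatter) and a 6600-fold lower number from compound 1 to compound 4 (3.82 log units; beyond the scatter), which shows that the chlorine is not required for a low number at this position. No measured evidence is available to explain why these two chain ends read alike.

From the compounds shown here alone, it remains open whether a carboxylic acid or an amine at the end of the same chain would also keep the number low, which would show whether the high numbers of the two acid-bearing compounds go with the acid itself or with the absence of the chain. A shorter chain, a longer chain and a plain ethyl group with nothing at its end are also untested among the compounds shown, so the part played by chain length remains unknown.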